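Sulfonamide aryl swap on the compound 2 core

This account rests on a few compounds, and the source may have more. Where it says the series, first, only, none or still open, it means among the compounds named here.

Measured so far:
compound 1 `CC(C)c1ccccc1OCC(C)N1CCC(NS(=O)(=O)c2ccc(F)cc2)CC1` — 74 nM
compound 2 `CC(COc1ccccc1-c1ccccc1)N1CCC(NS(=O)(=O)c2cccc(Cl)c2)CC1` — 32 nM

Two compounds carry numbers in an assay on HEK293 cells for displacement of a labelled ligand from 5-hydroxytryptamine receptor 7 (Homo sapiens), read by scintillation counting, with a stated time of 1 h; a higher number here means a weaker inhibitor, a lower number a stronger inhibitor. Compound 1 `CC(C)c1ccccc1OCC(C)N1CCC(NS(=O)(=O)c2ccc(F)cc2)CC1` gives 74 nM in this assay. Compound 2 `CC(COc1ccccc1-c1ccccc1)N1CCC(NS(=O)(=O)c2cccc(Cl)c2)CC1` gives 32 nM in this assay, the lowest of the two numbers; the gap to compound 1 is beyond the scatter. Compound 1 and compound 2 differ in two places at once, so no single change can be read off between them.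

Compound 3 `CC(COc1ccccc1-c1ccccc1)N1CCC(NS(=O)(=O)c2ccc(F)cc2)CC1` keeps the core of compound 2 and alters only the sulfonamide aryl: 4-fluorophenyl in place of 3-chlorophenyl on a sulfonyl sulfur. Within the data shown here, the 4-fluorophenyl sulfonamide is the one carried by compound 1, but on a different core, so that pairing says nothing direct about the step here. Among the measured compounds shown here, with no matched step on record, the change is expected to be small, on the weaker side if anything, and may well fall inside the scatter.

The estimate for compound 3 in this assay is 50 nM, with a range from 20 nM to 130 nM. This corresponds to an expected step of a 1.6-fold higher number from compound 2 to compound 3 (0.19 log units; within the scatter).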

Compound 3, inhibition constant: 34 nM
Beside the measured number, compound 3's estimate is 1.5-fold (0.17 log units) above it; low and high end bracket the measured number.
By their numbers in this assay, from the lowest: compounds 2 and 3 (each within the scatter of the next); then compound 1.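

In this assay, 4-fluorophenyl in place of 3-chlorophenyl on a sulfonyl sulfur gives a 1.1-fold higher number from compound 2 to compound 3 (0.03 log units; within the scatter), so the two aryl groups cannot be told apart at this position on the core of compound 2. Compound 3 also turns the earlier two-place comparison into a one-place one: with the 4-fluorophenyl sulfonamide held constant, phenyl in place of isopropyl on an aromatic carbon gives a 2.2-fold lower number from compound 1 to compound 3 (0.34 log units; beyond the scatter), a modest step that accounts for about as much as the whole gap printed earlier between the first two compounds. Nothing measured here bears on what lies behind either step.

The two aryl groups differ in both the halogen and its place on the ring, so a 3-fluorophenyl or 4-chlorophenyl group would be needed to separate those two changes, and a pyridyl ring or an aryl group carrying a carboxylic acid would test how far the flat reading extends. Whether the isopropyl core responds in the same way to the sulfonamide aryl swap also stays open, since the compounds shown carry the 3-chlorophenyl group only on the core of compound 2.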